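Oxan-4-yl to cyclopentyl on a carbonyl carbon

The source may hold more compounds than are shown below. What is called first, only, known or untested is meant among the compounds shown, and "the series" means these compounds.

Compound 1 `Cc1ccc(C(=O)Nc2cn3ncnc3c(CN3CCN(C(=O)CCC(F)(F)F)[C@@H](C)C3)c2C)cn1` and compound 2 `Cc1ccc(C(=O)Nc2cn3ncnc3c(CN3CCN(C(=O)C4CCOCC4)[C@@H](C)C3)c2C)cn1` share a core and differ only in the group on a carbonyl carbon. In an ADME assay on microsomes from liver (Homo sapiens) for metabolic stability (a lower number here means slower removal, a higher number faster removal of the compound), compound 2 gives < 10 mL.min-1.g-1, which is a limit of the assay. Compound 1 gives < 10 mL.min-1.g-1, which is also a limit. Among the measured compounds shown here, the one measured step, a step that the two limits leave unreadable from compound 1 to compound 2, therefore has no readable size. Compound 3 `Cc1ccc(C(=O)Nc2cn3ncnc3c(CN3CCN(C(=O)C4CCCC4)[C@@H](C)C3)c2C)cn1` keeps the core and changes the same group: cyclopentyl in place of oxan-4-yl on a carbonyl carbon. Since the two measured compounds both sit at one limit (the limit of < 10 mL.min-1.g-1 in this assay, at which 2 of the 2 values shown sit), only a modest move in this assay is expected, upward if at all, and not clearly beyond the scatter. The expected step, a number no lower from compound 2 to compound 3 (the limit leaves the size open), is accordingly small. For compound 3 the estimate is 10 mL.min-1.g-1, with an expected range of 5 mL.min-1.g-1 to 25 mL.min-1.g-1.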

Compound 3, intrinsic clearance in microsomes: 32 mL.min-1.g-1
Compound 3: the middle estimate sits 3.2-fold (0.51 log units) below what was measured, outside the stated range (above it).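

In this assay, the group on the carbonyl carbon now makes a readable difference: cyclopentyl in place of oxan-4-yl gives an at least 3.2-fold higher number from compound 2 to compound 3 (0.50 log units; beyond the scatter), and cyclopentyl in place of 3,3,3-trifluoropropyl gives an at least 3.2-fold higher number from compound 1 to compound 3 (0.50 log units; beyond the scatter). The shared core therefore does not keep every member of the series at the limit, as cyclopentyl leaves it while oxan-4-yl and 3,3,3-trifluoropropyl remain there. Both steps are lower bounds, since each starts from a limit and not a number: the limit of < 10 mL.min-1.g-1 in this assay, at which 2 of the 3 values shown sit.

As far as these compounds go, compound 3 changes ring size and removes the ring oxygen in one move, so the contribution of each stays open, and a cyclohexyl group would help separate them. The step between compound 1 and compound 2 still cannot be read.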